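The source may hold more compounds than are shown below. What is called first, only, known or untested is meant among the compounds shown, and "the series" means these compounds.

Compound 1 `CCCC(CCO)n1cnc2c(Cl)nc(F)nc21`: 16500 nM
Compound 2 `CCCCC(CCO)n1cnc2c(Cl)nc(F)nc21`: 13500 nM
Compound 3 `CCCCCC(CCO)n1cnc2c(Cl)nc(F)nc21`: 8660 nM

These three compounds were tested in a functional assay on HCT-116 cells (Homo sapiens) for antiproliferative activity, read by MTT assay, with a stated time of 48 h; on this read-out lower numbers stand for stronger inhibition and higher numbers for weaker inhibition. Compound 3, at 8660 nM, lies within the scatter of both others: a 1.9-fold lower number from compound 1 to compound 3 (0.28 log units; within the scatter) and a 1.6-fold lower number from compound 2 to compound 3 (0.19 log units; within the scatter). Compound 4 `CCCCCCC(CCO)n1cnc2c(Cl)nc(F)nc21`, not yet measured, differs from compound 3 in one place: methyl in place of hydrogen on a saturated chain carbon, six bonds along the chain from an aromatic nitrogen. The closest guides are the same kind of change made on the chain one and two bonds closer to the aromatic nitrogen: a 1.6-fold lower number from compound 2 to compound 3 (0.19 log units; within the scatter) and a 1.2-fold lower number from compound 1 to compound 2 (0.09 log units; within the scatter). Neither goes beyond the scatter, so no step beyond the scatter is expected in this assay here. The expected step is a 1.2-fold lower number from compound 3 to compound 4 (0.09 log units; within the scatter). For compound 4 the estimated value is 7000 nM, with an expected range of 3500 nM to 14000 nM.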

Compound 4, half-maximal inhibitory concentration: 9960 nM
Estimate against measurement, compound 4: 1.4-fold (0.15 log units) below; low and high end bracket the measured number.
By their numbers in this assay, from the lowest: compounds 3, 4, 2 and 1 (each within the scatter of the next).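

Putting methyl six bonds along the chain from an aromatic nitrogen gives a 1.2-fold higher number from compound 3 to compound 4 (0.06 log units; within the scatter), so the change stays within the scatter this far out as well. Ethyl and propyl, each set on a shorter chain, read the same way, with a 1.4-fold lower number from compound 2 to compound 4 (0.13 log units; within the scatter) and a 1.7-fold lower number from compound 1 to compound 4 (0.22 log units; within the scatter), so no chain length among these four compounds stands apart. The methyl change also reads alike at two places on the chain: the same change on two cores in this assay, a 1.2-fold lower number (0.09 log units; within the scatter) from compound 1 to compound 2 and a 1.2-fold higher number (0.06 log units; within the scatter) from compound 3 to compound 4, 1.4-fold (0.15 log units) apart, within the scatter of two such steps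

From the compounds shown here alone, whether an amine or a carboxylic acid in place of this methyl would give a step beyond the scatter stays open. So does the effect of a longer chain.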